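The source may hold more compounds than are shown below. What is called first, only, known or untested is meant among the compounds shown, and "the series" means these compounds.

Working notes on the series. Compound 1 `ClCc1ccc(Cn2cnc3c(Cl)ncnc32)cc1` and compound 2 `ClCc1cccc(Cn2cnc3ncnc(Cl)c32)c1` share a core and differ in where the chloromethyl-bearing arm is attached; both were tested in a functional assay on CCRF-CEM cells (Homo sapiens) for cytotoxicity, read by sulforhodamine B assay, with a stated time of 48 h; a higher number here means a weaker inhibitor of growth, a lower number a stronger inhibitor of growth. For compound 1 the result is only a limit, > 100000 nM, so no number is known for it (the limit of > 100000 nM in this assay, at which 1 of the 2 values shown sits). Compound 2 gives 22400 nM in this assay, a measured number. Among the measured compounds shown here, no step between measured compounds can be drawn from this pair. Compound 3 `ClCc1ccc(Cn2cnc3c(Cl)nc(Cl)nc32)cc1` is not yet measured. It differs from compound 1 by chloro in place of hydrogen on an aromatic carbon. Since compound 1 stands only at the limit, the size of the step cannot be anchored to a measured value; the expectation is for no step beyond the scatter, or at most a modest gain. Compound 3 is accordingly estimated at 60000 nM, range 15000 nM to 200000 nM, which as a step from compound 1 to compound 3 means an at least 1.6-fold lower number from compound 1 to compound 3 (0.22 log units; that floor lies within the scatter).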

Compound 3, concentration for total growth inhibition: 4570 nM
Compound 3: the middle estimate sits 13-fold (1.12 log units) above what was measured; measured number below the stated range.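

In this assay, among the compounds shown here, chloro in place of hydrogen on an aromatic carbon between two ring nitrogen atoms gives an at least 21-fold lower number from compound 1 to compound 3 (1.34 log units; beyond the scatter), the first step that can be stated and one beyond the scatter. For the compounds shown here, this shows that growth inhibition responds to a change at this carbon, which the earlier compounds, differing only in where the arm is attached, could not show. The value of compound 1 is a limit and not a number, so the step gives only a lower bound on the change: the limit of > 100000 nM in this assay, at which 1 of the 3 values shown sits.

Going by these compounds, whether the response is specific to chloro remains open, as an amine, a methoxy group or a fluoro at this carbon would test. Also open, on these data alone, is whether chloro at this carbon would move the number by a similar amount on the arm arrangement of compound 2.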